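The source may hold more compounds than are shown below. What is called first, only, known or untested is meant among the compounds shown, and "the series" means these compounds.

In a functional assay on HEL cells (Homo sapiens) for cytotoxicity (a lower number here means that less compound is tolerated, a higher number that more compound is tolerated), compound 1 (`CCCCCCCCC#Cc1cc2cn([C@H]3C[C@H](O)[C@@H](CO)O3)c(=O)nc2o1`) gives 77000 nM. Compound 2 (`CCCCCCCCC#Cc1cc2cn(C)c(=O)nc2o1`) is reported only as a limit, > 175000 nM. Its true value is therefore not known, and it offers a limit rather than a firm starting point.

The next compound, compound 3 (`CCCCCCCCC#Cc1cc2cn([C@@H]3O[C@H](CO)[C@@H](O)[C@@H]3O)c(=O)nc2o1`), keeps the shared core and the long alkynyl chain but changes the group on the aromatic nitrogen: 3,4-dihydroxy-5-(hydroxymethyl)oxolan-2-yl in place of methyl on an aromatic nitrogen. In words, 3,4-dihydroxy-5-(hydroxymethyl)oxolan-2-yl takes the place of methyl.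

Going by the values given here, one measured step bears on this change: an at least 2.2-fold higher number from compound 1 to compound 2 (0.35 log units; beyond the scatter). There, methyl replaced the closely related 4-hydroxy-5-(hydroxymethyl)oxolan-2-yl. Compound 3 restores an oxolane-bearing group of that kind, so the step is expected to run largely in reverse, towards a lower number of roughly similar size. Among the compounds with values here, the limit on compound 2 leaves the true size open, and the added hydroxyl of compound 3 has no measured precedent here.

The expected change is an at least 1.9-fold lower number from compound 2 to compound 3 (0.28 log units; that floor lies within the scatter). Compound 3 is estimated at 90000 nM, with an expected range from 35000 nM to 230000 nM.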

Compound 3, half-maximal cytotoxic concentration: > 124000 nM
Compound 3: only a limit was reported (the forecaster's own chance of this, stated with the estimate: 35%); at least 1.3-fold (0.13 log units) between middle value and limit.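

In this assay compound 3 is reported only as a limit, > 124000 nM. Going by these compounds alone, its comparison with compound 1 is the one readable step, and hydroxy in place of hydrogen on a saturated ring carbon gives an at least 1.6-fold higher number from compound 1 to compound 3 (0.20 log units; that floor lies within the scatter). Within the data shown here, this adds something that the earlier compounds did not show: carrying an oxolane-bearing group on the aromatic nitrogen does not by itself fix the number at the level of compound 1, although the floor of this step is too small to establish a real separation. The step between the methyl compound and compound 3 cannot be read, since both ends are limits, so the exchange of methyl for 3,4-dihydroxy-5-(hydroxymethyl)oxolan-2-yl has no measurable size here.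

The compounds shown leave open where the true values of compound 2 and compound 3 lie, and therefore whether the added hydroxy truly raises the number. They also leave open how an amine in place of that hydroxy, or a shorter chain in place of the long alkynyl chain, would behave on the shared core.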